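Solubility of Three Anilides and an Estimate for Compound 4

The compounds below may be only part of what the source reports. "The series", "measured", "known", "first", "only" and "open" are said of these compounds alone.

Measured so far in a physicochemical assay for solubility, in phosphate buffer, measured as kinetic solubility, with a stated time of 1 h, at pH 7.4; on this read-out higher numbers stand for higher solubility and lower numbers for lower solubility:
compound 1, `COc1ccc2nc(C)cc(OCC(=O)Nc3c(C)cccc3C)c2c1`, gives 112000 nM;
compound 2, `COc1ccc2nc(C)cc(OCC(=O)Nc3cc(C)c(F)c(C)c3)c2c1`, gives 31500 nM;
compound 3, `COc1ccc2nc(C)cc(OCC(=O)Nc3ccc(Br)c(C)c3)c2c1`, gives < 1000 nM, which is a limit of the assay and not a number.

All three share one core and differ only in the aryl group on the amide-type nitrogen. Compound 1 sits highest, and the step of a 3.6-fold lower number from compound 1 to compound 2 (0.55 log units; beyond the scatter) is modest. Compound 3 reaches (the limit of < 1000 nM in this assay, at which 1 of the 3 values shown sits), so only a ceiling is known for it. The steps of an at least 110-fold lower number from compound 1 to compound 3 (2.04 log units; beyond the scatter) and an at least 31-fold lower number from compound 2 to compound 3 (1.49 log units; beyond the scatter) are both large, placing compound 3 far beneath the other two.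

Compound 4, `COc1ccc2nc(C)cc(OCC(=O)Nc3ccc(Cl)cc3)c2c1`, has not been measured. The change 4-chlorophenyl in place of 4-bromo-3-methylphenyl on an amide-type nitrogen removes the methyl and exchanges bromine for chlorine. Within the data shown here, no measured step matches this change, and the limit on compound 3 leaves its own position open. The two large steps toward compound 3 suggest that its aryl group pulls solubility down; a smaller halogen without the methyl is expected to lift it somewhat, giving an estimated step of an at least 3.0-fold higher number from compound 3 to compound 4 (0.47 log units; beyond the scatter). Compound 4 is therefore expected near 3000 nM, within 700 nM to 15000 nM.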

Compound 4, solubility: 9000 nM
Beside the measured number, compound 4's estimate is 3.0-fold (0.48 log units) below it, within the range that was stated.
By their numbers in this assay, from the lowest: compound 4; then compound 2; then compound 1. At a limit, below all of these: compound 3.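

Exchanging 4-bromo-3-methylphenyl for 4-chlorophenyl gives an at least 9.0-fold higher number from compound 3 to compound 4 (0.95 log units; beyond the scatter) in this assay and shows that a halogen-bearing aryl group without a methyl can stay clear of the bottom of the range. The size of that step remains a minimum, since compound 3 stands at a limit and not a number: the limit of < 1000 nM in this assay, at which 1 of the 4 values shown sits. Compound 4 still lies under the two compounds with dimethylphenyl rings, with a 3.5-fold lower number from compound 2 to compound 4 (0.54 log units; beyond the scatter) and a 12-fold lower number from compound 1 to compound 4 (1.09 log units; beyond the scatter) on the same amide-type nitrogen, so this position now has a measured middle rung between them and the limit.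

This change removes a methyl and exchanges bromine for chlorine in one move, so the compounds shown cannot divide the step between the two, as a 4-bromophenyl group could. Also open, from the compounds shown here alone, is how this read-out would respond to an aryl group carrying an amine or a carboxylic acid in place of the halogen.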